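Nitro in Place of Phenoxy: Cytotoxicity Expected to Stay Unreadable

The source may hold more compounds than are shown below. What is called first, only, known or untested is meant among the compounds shown, and "the series" means these compounds.

Compound 1 `CC(C)N(Cc1cccc(OCCCCCC(=O)O)c1)C(=O)c1ccc(-c2cccc(Oc3ccccc3)c2)cc1` is tested in an ADME assay on Raji cells (Homo sapiens) for cytotoxicity, read by CellTiter-Glo and resazurin assay, with a stated time of 72 h; on this read-out lower numbers stand for an effect already at smaller amounts and higher numbers for an effect only at larger amounts of compound. Its value is only a limit: compound 1 gives > 18700 nM. Compound 2 `COc1cccc(-c2ccc(C(=O)N(Cc3cccc(OCCCCCC(=O)O)c3)C(C)C)cc2)c1` likewise gives only a limit, > 20900 nM. Compound 3 `CC(C)N(Cc1cccc(OCCCCCC(=O)O)c1)C(=O)c1ccc(-c2cccc(C(F)(F)F)c2)cc1` also gives only a limit, > 26000 nM. Every step among them is therefore unreadable: a step that the two limits leave unreadable from compound 1 to compound 2, a step that the two limits leave unreadable from compound 1 to compound 3 and a step that the two limits leave unreadable from compound 2 to compound 3. Compound 4 `CC(C)N(Cc1cccc(OCCCCCC(=O)O)c1)C(=O)c1ccc(-c2cccc([N+](=O)[O-])c2)cc1` differs from compound 1 by nitro in place of phenoxy on an aromatic carbon. The steps to compound 2 and compound 3 alter the same aromatic carbon and bear on this change, yet they give no size. Because all three values sit at limits (the limit of > 18700 nM in this assay, at which 1 of the 3 values shown sits), (the limit of > 20900 nM in this assay, at which 1 of the 3 values shown sits), (the limit of > 26000 nM in this assay, at which 1 of the 3 values shown sits), compound 4 is expected to give only a limit as well, with a step that the limit leaves unreadable from compound 1 to compound 4 unreadable. The estimate for compound 4 is 25000 nM, within 8000 nM to 80000 nM.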

Compound 4, half-maximal effective concentration: > 26000 nM
Compound 4 gave a limit, no number (the forecaster's own chance of this, stated with the estimate: 80%); middle value at least 1.0-fold (0.01 log units) away from the limit.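

Among these compounds, compound 4 gives only the limit > 26000 nM in this assay and so no step from compound 1, compound 2 or compound 3 to compound 4 can be read. The compounds shown leave open whether phenoxy, methoxy, trifluoromethyl and nitro differ at all on this read-out.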